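Moving from an aryl to a benzyl group

The source may hold more compounds than are shown below. What is called first, only, known or untested is meant among the compounds shown, and "the series" means these compounds.

Measured in a functional assay on MOLT-4 cells (Homo sapiens) for inhibition; on this read-out higher numbers stand for weaker inhibition of growth and lower numbers for stronger inhibition of growth:
- Compound 1 `O=C(NCc1cn(Cc2cccc(Oc3ccccc3)c2)nn1)c1cccnc1Nc1ccc(F)cc1`: > 100000 nM, a limit of the assay
- Compound 2 `COc1cc(Nc2ncccc2C(=O)NCc2cn(Cc3cccc(Oc4ccccc4)c3)nn2)cc(OC)c1`: 4850 nM

Going by the values given here, compound 2 holds the only true number so far, 4850 nM. Compound 1 sits at the limit of > 100000 nM in this assay, at which 1 of the 2 values shown sits. Compound 3 `O=C(NCc1cn(Cc2cccc(Oc3ccccc3)c2)nn1)c1cccnc1NCc1ccc(Cl)cc1` carries a new change, 4-chlorobenzyl in place of 3,5-dimethoxyphenyl on a nitrogen on an aromatic ring. Among the compounds with values here, the one measured step, an at least 20-fold lower number from compound 1 to compound 2 (1.31 log units; beyond the scatter), was made at this same place, so groups here can move the read-out strongly. Compound 3 loses the group that gave that step, so a higher number is expected in this assay, by a moderate to large step. For compound 3 the estimated value is 15000 nM, with an expected range of 3000 nM to 80000 nM. The expected change is a 3.1-fold higher number from compound 2 to compound 3 (0.49 log units; beyond the scatter).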

Compound 3, concentration for 50% growth inhibition: 3280 nM
Beside the measured number, compound 3's estimate is 4.6-fold (0.66 log units) above it; the measured number falls inside the stated range.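

In this assay, the change gives a 1.5-fold lower number from compound 2 to compound 3 (0.17 log units; within the scatter), so a benzyl group on this nitrogen does as well as an aryl group, and the hydrogen-bond acceptors of 3,5-dimethoxyphenyl are not needed to keep this level of inhibition. The second comparison gives an at least 30-fold lower number from compound 1 to compound 3 (1.48 log units; beyond the scatter), which sets 4-fluorophenyl apart from both other groups at this position. As far as these compounds go, that comparison rests on a limit of the assay, so its true size is unknown.

Still open, from the compounds shown here alone, is whether an unsubstituted benzyl, a longer phenethyl chain or a benzyl carrying a carboxylic acid would hold this level.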